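Isopropyl for trifluoromethyl on the anilino ring of compound 3

The source may report more compounds than this note shows. Statements on the series, on what has been measured and on what is new or still open speak of the compounds shown alone.

Measured compounds:
compound 1, `CNC(=O)c1ccccc1Oc1nc(Nc2ccccc2F)ncc1Br`, > 50000 nM
compound 2, `CNC(=O)c1ccccc1Oc1nc(Nc2ccc(C)cc2C)ncc1Br`, 32300 nM
compound 3, `CNC(=O)c1ccccc1Oc1nc(Nc2cccc(C(F)(F)F)c2)ncc1Br`, 44000 nM

Of the compounds shown here, three sharing one core have been tested in a functional assay on HL-60 cells (Homo sapiens) for antiproliferative activity, read by MTT assay, with a stated time of 24 h; a higher number here means a weaker inhibitor, a lower number a stronger inhibitor. Compound 1 (`CNC(=O)c1ccccc1Oc1nc(Nc2ccccc2F)ncc1Br`) gives > 50000 nM, which is a limit of this assay and not a number (the limit of > 50000 nM in this assay, at which 1 of the 3 values shown sits). Compound 2 (`CNC(=O)c1ccccc1Oc1nc(Nc2ccc(C)cc2C)ncc1Br`) gives 32300 nM. Compound 3 (`CNC(=O)c1ccccc1Oc1nc(Nc2cccc(C(F)(F)F)c2)ncc1Br`) gives 44000 nM. The two numbers for compound 2 and compound 3 sit within the usual scatter of one another, so neither can be placed above the other.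

For the measured compounds named here, the one step that can be read between measured compounds is an at least 1.5-fold lower number from compound 1 to compound 2 (0.18 log units; that floor lies within the scatter); it runs from a limit and lies within the scatter, and it concerns a different change on the anilino ring than the one considered now.

Compound 4 (`CNC(=O)c1ccccc1Oc1nc(Nc2cccc(C(C)C)c2)ncc1Br`) differs from compound 3 in one place: isopropyl in place of trifluoromethyl on an aromatic carbon. Going by the values given here, no measured step mirrors this exchange, and the single step available gives no sign that substituents on that ring move the number beyond the scatter. Compound 4 is therefore expected to sit close to compound 3, with a 1.1-fold lower number from compound 3 to compound 4 (0.04 log units; within the scatter) as the estimated step. The value estimated for compound 4 in this assay is 40000 nM, with a range from 15000 nM to 110000 nM.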

Compound 4, half-maximal inhibitory concentration: 17500 nM
Compound 4: the middle estimate sits 2.3-fold (0.36 log units) above what was measured; measured number inside the range.
By their numbers in this assay, from the lowest: compounds 4, 2 and 3 (each within the scatter of the next, the first and the last beyond it). At a limit, above all of these: compound 1.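

In this assay, for the compounds shown here, isopropyl in place of trifluoromethyl, on an aromatic carbon meta to a large group, gives the first step between two measured numbers on this ring that lies beyond the scatter, so this place does respond to the group it carries: a 2.5-fold lower number from compound 3 to compound 4 (0.40 log units; beyond the scatter). Compound 4 cannot be separated from the differently substituted compound 2, since a 1.8-fold lower number from compound 2 to compound 4 (0.27 log units; within the scatter) stays within the scatter, and the change at this place therefore shows no clear gain over the 2,4-dimethylphenyl ring. Compound 1 stands at a limit and not at a number, so the step of an at least 2.8-fold lower number from compound 1 to compound 4 (0.45 log units; beyond the scatter) can be read only as a floor: the limit of > 50000 nM in this assay, at which 1 of the 4 values shown sits.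

A single exchange at this place cannot show which feature of isopropyl goes with the lower number, and no cause for the step can be drawn from these compounds. Going by these compounds, it also remains open whether a tert-butyl group, a methoxy group or an amine at the same place would lower the number further, and whether isopropyl would give a similar step elsewhere on the ring.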